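Ethoxy in place of methoxy on the aryl group

The source may report more compounds than this note shows. Statements on the series, on what has been measured and on what is new or still open speak of the compounds shown alone.

Within the data shown here, compound 2 `COc1ccccc1-c1nc2cc(C(F)(F)F)ccc2[nH]1` gives 210000 nM in a functional assay on aorta (Rattus norvegicus, strain Wistar) for inhibition, with a stated time of 60 min (a lower number here means that less compound is needed, a higher number that more compound is needed for the effect), the higher of the two numbers measured so far; its only neighbour, compound 1 `O=[N+]([O-])c1ccccc1-c1nc2cc(C(F)(F)F)ccc2[nH]1`, gives 3180 nM in this assay. Among the measured compounds shown here, the one measured step, a 66-fold higher number from compound 1 to compound 2 (1.82 log units; beyond the scatter), concerns an exchange on an aromatic carbon and not the chain on the oxygen. Compound 3 `CCOc1ccccc1-c1nc2cc(C(F)(F)F)ccc2[nH]1` differs from compound 2 by methyl in place of hydrogen on a saturated chain carbon bound to an oxygen on an aromatic ring. For the measured compounds named here, no measured step in this small set bears on a change of this kind; the step from compound 1 to compound 2 tells only that the methoxy compound sits far up the scale. With nothing shown for lengthening the chain on the oxygen, the expected step is none beyond the scatter, no change at the digits printed from compound 2 to compound 3 (within the scatter). For compound 3 the estimate in this assay is 210000 nM, with a range from 60000 nM to 700000 nM.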

Compound 3, half-maximal effective concentration: 549000 nM
Estimate against measurement, compound 3: 2.6-fold (0.42 log units) below; low and high end bracket the measured number.
By their numbers in this assay, from the lowest: compound 1; then compound 2; then compound 3.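

In this assay the chain on the oxygen is not silent: methoxy to ethoxy, a methyl in place of hydrogen on a saturated chain carbon bound to an oxygen on an aromatic ring, gives a 2.6-fold higher number from compound 2 to compound 3 (0.42 log units; beyond the scatter) and so moves the number modestly further up. Exchanging the nitro group for ethoxy gives a 170-fold higher number from compound 1 to compound 3 (2.24 log units; beyond the scatter) and is the largest step in this set, leaving compound 1 with the lowest number and compound 3 with the highest. Nothing measured here accounts for either step.

Among these compounds, two alkoxy compounds give only one step along the chain, so whether a longer chain such as propoxy raises the number further remains open. Also open, going by these compounds, is whether an amine or a carboxylic acid on that aromatic carbon would give a number nearer that of compound 1 or nearer those of the alkoxy compounds.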